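Trifluoromethyl in place of fluoromethyl: carrying the step over

The source may report more compounds than this note shows. Statements on the series, on what has been measured and on what is new or still open speak of the compounds shown alone.

In a functional assay (aorta) with Rattus norvegicus as the target (a lower number here means that less compound is needed, a higher number that more compound is needed for the effect), compound 1 `CNC(=O)C1=CC(C)(CF)Oc2ccc([N+](=O)[O-])cc21` gives 8.91 nM. Compound 2 `CNC(=O)C1=CC(C)(C(F)(F)F)Oc2ccc([N+](=O)[O-])cc21` carries trifluoromethyl in place of fluoromethyl on a saturated ring carbon and in this assay compound 2 gives 2.69 nM; the step is a 3.3-fold lower number from compound 1 to compound 2 (0.52 log units; beyond the scatter). Compound 3 `CC1(CF)C=C(C(=O)NCCC#N)c2cc([N+](=O)[O-])ccc2O1` differs from compound 1 by cyanomethyl in place of hydrogen on a saturated chain carbon bound to an amide-type nitrogen, and in this assay compound 3 gives 3.98 nM; the step is a 2.2-fold lower number from compound 1 to compound 3 (0.35 log units; beyond the scatter). The values of compound 2 and compound 3 lie within the scatter of each other.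

Compound 4 `CC1(C(F)(F)F)C=C(C(=O)NCCC#N)c2cc([N+](=O)[O-])ccc2O1` is not yet measured. It differs from compound 3 by trifluoromethyl in place of fluoromethyl on a saturated ring carbon. This is the same kind of change as from compound 1 to compound 2, not the same: around the place, the ring atom two ring bonds away bears a (2-cyanoethyl)carbamoyl group (7 heavy atoms) in compound 3, a methylcarbamoyl group (4 heavy atoms) in compound 1.

A step of a 2.8-fold lower number from compound 3 to compound 4 (0.45 log units; beyond the scatter) is expected, resting on a 3.3-fold lower number from compound 1 to compound 2 (0.52 log units; beyond the scatter) applied to compound 3 at 3.98 nM, tempered a little; the change has been seen in one pair only. Compound 4 is estimated at 1.4 nM, with a range from 0.6 nM to 3.5 nM.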

Compound 4, half-maximal effective concentration: 0.692 nM
For compound 4 the middle estimate is 2.0-fold (0.31 log units) above the measured one; the measured number falls inside the stated range.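

Trifluoromethyl in place of fluoromethyl on a saturated ring carbon carries over to the (2-cyanoethyl)carbamoyl core in this assay, giving a 5.8-fold lower number from compound 3 to compound 4 (0.76 log units; beyond the scatter), and the size of the step agrees with that on the methylcarbamoyl core: the same change on two cores in this assay, a 3.3-fold lower number (0.52 log units; beyond the scatter) from compound 1 to compound 2 and a 5.8-fold lower number (0.76 log units; beyond the scatter) from compound 3 to compound 4, 1.7-fold (0.24 log units) apart, within the scatter of two such steps. Cyanomethyl in place of hydrogen on the chain carbon bound to the amide-type nitrogen likewise carries over from the fluoromethyl to the trifluoromethyl compounds, giving a 3.9-fold lower number from compound 2 to compound 4 (0.59 log units; beyond the scatter), again in agreement with the earlier step: the same change on two cores in this assay, a 2.2-fold lower number (0.35 log units; beyond the scatter) from compound 1 to compound 3 and a 3.9-fold lower number (0.59 log units; beyond the scatter) from compound 2 to compound 4, 1.7-fold (0.24 log units) apart, within the scatter of two such steps. The two changes therefore look additive within the scatter in this assay, but both comparisons rest on the same four compounds, so they form a single test and show neither a general rule for the series nor any reason for the steps.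

Still open, going by these compounds, is whether the trifluoromethyl step holds when the amide carries a longer chain, or an amine or a carboxylic acid at the chain end. Also open, on these data alone, is where difluoromethyl on the same saturated ring carbon would fall.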